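Oral exposure notes: from compound 2 to compound 4

A few compounds are considered here, and "the series" means these few. Any claim that something is new, unique, unknown or untested is made for them only; others in the source may bear on it.

- compound 1 `Cc1ccncc1C(=O)N1CC(Oc2cncc(N3C(=O)c4ccc(Cl)cc4C3(C)C)c2)C1` gives 40% as its reading
- compound 2 `CC1(C)c2cc(Cl)ccc2C(=O)N1c1cncc(OC2CN(C(=O)c3ncccc3Cl)C2)c1` gives 58% as its reading
- compound 3 `Cn1cc(C(=O)N2CC3(C2)CN(c2cncc(N4C(=O)c5ccc(Cl)cc5C4(C)C)c2)C3)cn1` gives 69% as its reading

In an ADME assay on the whole organism (Rattus norvegicus, strain Wister-Han) for pharmacokinetics, read by LC-MS, at a dose of 3 mg/kg by the oral route (a lower number here means that a smaller share of the oral dose reaches the circulation, a higher number that a larger share of the oral dose reaches the circulation), compound 2 stands second highest of the three, under compound 3 and over compound 1. The next change gives compound 4 `CCS(=O)(=O)N1CC(Oc2cncc(N3C(=O)c4ccc(Cl)cc4C3(C)C)c2)C1` through ethylsulfonyl in place of (3-chloropyridin-2-yl)carbonyl on an amine nitrogen in a ring on an amine nitrogen in a ring, with the rest of the structure kept. Going by the values given here, the only measured step that bears on this, a number 18 percentage points higher from compound 1 to compound 2 (beyond the scatter), exchanges one pyridinyl carbonyl group for another. Among the compounds with values here, no measured compound carries a sulfonyl group, so the direction is open. In this assay an estimated a number 6 percentage points lower from compound 2 to compound 4 (within the scatter) is therefore expected, most likely no step beyond the scatter. For compound 4 an estimated 52% is expected, with 28% to 75% as the range.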

Compound 4, oral bioavailability: 45%
Beside the measured number, compound 4's estimate is 7 percentage points above it; low and high end bracket the measured number.
By their numbers in this assay, from the lowest: compounds 1 and 4 (each within the scatter of the next); then compound 2; then compound 3.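

In this assay ethylsulfonyl on this amine nitrogen gives a number 13 percentage points lower from compound 2 to compound 4 (beyond the scatter) and also a number 5 percentage points higher from compound 1 to compound 4 (within the scatter) with the rest of the structure kept. A group with no ring and no carbonyl therefore holds the reading of (4-methylpyridin-3-yl)carbonyl at this position but does not match (3-chloropyridin-2-yl)carbonyl. Nothing available accounts for either step.

Open, as far as these compounds go, is whether methylsulfonyl, a longer chain on the sulfonyl or phenylsulfonyl would read differently from ethylsulfonyl. Also open, from the compounds shown here alone, is how a simple alkyl amide would compare at this nitrogen.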